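A few compounds are considered here, and "the series" means these few. Any claim that something is new, unique, unknown or untested is made for them only; others in the source may bear on it.

Compound 3 `CCCn1c(=O)n(C)c(=O)c2c1ncn2CC(N)=O` stands at a limit of an assay on Cerebral cortex for binding affinity to adenosine receptor A1 (Cavia porcellus), read by radioligand binding; on this read-out lower numbers stand for stronger inhibition and higher numbers for weaker inhibition: compound 3 gives > 200000 nM, so no number is known for it. Compound 1 `CCCn1c(=O)n(CC(=O)O)c(=O)c2[nH]cnc21` likewise gives only a limit in this assay, > 200000 nM. Compound 2 `CCCn1c(=O)n(CCCN(C)C)c(=O)c2[nH]cnc21` gives 43200 nM in this assay. Within the data shown here, the one step with a measured size, an at least 4.6-fold lower number from compound 1 to compound 2 (0.66 log units; beyond the scatter), also sits on a saturated chain carbon bound to an aromatic nitrogen and is read against (the limit of > 200000 nM in this assay, at which 2 of the 3 values shown sit). Compound 4 `CCCn1c(=O)n(C)c(=O)c2c1ncn2CCOCC` differs from compound 3 by ethoxymethyl in place of carbamoyl on a saturated chain carbon bound to an aromatic nitrogen. Given the size of an at least 4.6-fold lower number from compound 1 to compound 2 (0.66 log units; beyond the scatter), a smaller move toward stronger binding is expected here, an at least 1.6-fold lower number from compound 3 to compound 4 (0.22 log units; that floor lies within the scatter). Compound 4 is therefore estimated at 120000 nM, within a range from 30000 nM to 300000 nM, with a fair chance that this assay again reports only a limit.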

Compound 4, inhibition constant: 24300 nM
Estimate against measurement, compound 4: 4.9-fold (0.69 log units) above, outside the stated range (below it).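

In this assay, ethoxymethyl in place of carbamoyl on a saturated chain carbon bound to an aromatic nitrogen gives a change beyond the scatter, an at least 8.2-fold lower number from compound 3 to compound 4 (0.91 log units; beyond the scatter). This shows that a change at this place alone can bring a measured number out of the limit. The size is only a floor, because one end of the step is a limit: the limit of > 200000 nM in this assay, at which 2 of the 4 values shown sit.

The compounds shown leave open whether the ether oxygen matters or the chain alone suffices. A pentyl chain or an amine at this place would help to separate the two.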